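The compounds below may be only part of what the source reports. "The series", "measured", "known", "first", "only" and "open" are said of these compounds alone.

Going by the values given here, compound 1 `C=C(Br)C(=O)Nc1ccc(/C=C2\SC(=O)N(Cc3cccc(Cl)c3)C2=O)cc1` is one of two compounds measured in a functional assay on HeLa cells (Homo sapiens) for cytotoxicity, read by cell counting, with a stated time of 4 days; on this read-out lower numbers stand for stronger inhibition and higher numbers for weaker inhibition. Compound 1 gives 8900 nM, the highest of the two numbers shown. Among the compounds with values here, the other, compound 2 `C=C(Br)C(=O)Nc1cccc(/C=C2\SC(=O)N(Cc3ccccc3)C2=O)c1`, gives 1400 nM in this assay; it differs from compound 1 in more than one place, so no single step can be drawn between the two, and only the two numbers themselves stand side by side, with compound 2 the lower of them. Compound 3 `C=C(Br)C(=O)Nc1ccc(/C=C2\SC(=O)N(Cc3ccc(C(F)(F)F)cc3)C2=O)cc1` has not yet been measured. It differs from compound 1 in one place: 4-(trifluoromethyl)phenyl in place of 3-chlorophenyl on a saturated chain carbon bound to an amide-type nitrogen in a ring. Within the data shown here, nothing measured so far bears directly on this change, since no pair of measured compounds differs only in it. Compound 3 is therefore expected to show a 1.3-fold lower number from compound 1 to compound 3 (0.10 log units; within the scatter), a step within the usual scatter. Compound 3 is accordingly estimated at 7000 nM in this assay, with a range from 2500 nM to 20000 nM.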

Compound 3, half-maximal inhibitory concentration: 13000 nM
Estimate against measurement, compound 3: 1.9-fold (0.27 log units) below; the measured number falls inside the stated range.
By their numbers in this assay, from the lowest: compound 2; then compounds 1 and 3 (each within the scatter of the next).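

Going by these compounds alone, compound 1 and compound 3 form the first pair here that differs in one place, on a saturated chain carbon bound to an amide-type nitrogen in a ring. In this assay, putting 4-(trifluoromethyl)phenyl in place of 3-chlorophenyl gives a 1.5-fold higher number from compound 1 to compound 3 (0.16 log units; within the scatter), so for this pair the two different substituted phenyl groups cannot be told apart on this read-out. No measurement shown offers an explanation for this result.

The compounds shown leave open whether a group of another kind at this place, such as an amine, a carboxylic acid or a longer chain ending in a phenyl ring, would shift the number beyond the scatter. They also leave open which of its several differences sets compound 2 apart from compound 1 and compound 3.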